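Swapping a Tert-Butyl Group for a 2-Methylphenyl Group

A few compounds are considered here, and "the series" means these few. Any claim that something is new, unique, unknown or untested is made for them only; others in the source may bear on it.

Of the compounds shown here, three sharing one core have been tested in an assay on cells for agonist activity at probable G-protein coupled receptor 34 (Mus musculus), with a stated time of 1 h; on this read-out lower numbers stand for smaller maximal responses and higher numbers for larger maximal responses. Compound 1 `N[C@@H](COP(=O)(O)OCCCOC(=O)CCc1ccccc1OCc1cccc(Oc2ccc(Br)cc2)c1)C(=O)O` gives 17.7%, compound 2 `N#Cc1ccc(Oc2cccc(COc3ccccc3CCC(=O)OCCCOP(=O)(O)OC[C@H](N)C(=O)O)c2)cc1` gives 18.3%, and compound 3 `CC(C)(C)c1ccc(Oc2cccc(COc3ccccc3CCC(=O)OCCCOP(=O)(O)OC[C@H](N)C(=O)O)c2)cc1` gives 16.9%. Compound 3 holds the lowest of the three numbers, yet its steps to the others, a number 0.8 percentage points lower from compound 1 to compound 3 (within the scatter) and a number 1.4 percentage points lower from compound 2 to compound 3 (within the scatter), both lie within the scatter. Compound 4 `Cc1ccccc1-c1ccc(Oc2cccc(COc3ccccc3CCC(=O)OCCCOP(=O)(O)OC[C@H](N)C(=O)O)c2)cc1` differs from compound 3 by 2-methylphenyl in place of tert-butyl on an aromatic carbon. The steps that exchanged the group on this aromatic carbon, a number 0.6 percentage points higher from compound 1 to compound 2 (within the scatter) and a number 1.4 percentage points lower from compound 2 to compound 3 (within the scatter), stayed within the scatter, so no step beyond the scatter is expected in this assay. Compound 4 is therefore estimated at 17.5%, within 9% to 28%, an expected step of a number 0.6 percentage points higher from compound 3 to compound 4 (within the scatter).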

Compound 4, largest response reached (Emax), in percent of the reference or control that the assay uses: 13.4%
Compound 4: middle estimate off by 4.1 percentage points, on the high side, and the stated range covers the measured number.
By their numbers in this assay, from the lowest: compounds 4, 3, 1 and 2 (each within the scatter of the next).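

Even 2-methylphenyl, which brings a whole aromatic ring to this aromatic carbon, stays within the scatter in this assay: a number 3.5 percentage points lower from compound 3 to compound 4 (within the scatter), a number 4.9 percentage points lower from compound 2 to compound 4 (within the scatter) and a number 4.3 percentage points lower from compound 1 to compound 4 (within the scatter). Across bromo, cyano, tert-butyl and 2-methylphenyl, therefore, no exchange of this group has produced a step beyond the scatter, even with the added ring. No evidence is available that bears on this result. Still open, as far as these compounds go, is whether an amine or a carboxylic acid on this aromatic carbon would produce a step beyond the scatter.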